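Swapping the acetyl end of compound 3 for a dimethylamino chain

The compounds below may be only part of what the source reports. "The series", "measured", "known", "first", "only" and "open" are said of these compounds alone.

Three compounds share one core and differ only in the group carried on the pyrrolidine nitrogen. Compound 1 `CC(C)(C)OC(=O)N1CCC[C@@H]1C(=O)N1CCC(NS(=O)(=O)c2cc(S(=O)(=O)c3ccccc3)ccc2C(F)(F)F)CC1` gives 210 nM in a functional assay on U2OS cells for antagonist activity at proto-oncogene Wnt-3 (Homo sapiens), read by a luciferase reporter, with a stated time of 18 h; a lower number here means that less compound is needed, a higher number that more compound is needed for the effect. Compound 2 `O=C1CC[C@@H](C(=O)N2CCC(NS(=O)(=O)c3cc(S(=O)(=O)c4ccccc4)ccc3C(F)(F)F)CC2)N1` gives 240 nM in this assay, and compound 3 `CC(=O)N1CCC[C@H]1C(=O)N1CCC(NS(=O)(=O)c2cc(S(=O)(=O)c3ccccc3)ccc2C(F)(F)F)CC1` gives 250 nM. Compound 3 thus holds the top of these three numbers, yet its gap to compound 2 and to compound 1 lies within the scatter, so no order can be read from them. The steps measured so far, a 1.1-fold higher number from compound 1 to compound 2 (0.06 log units; within the scatter), a 1.2-fold higher number from compound 1 to compound 3 (0.08 log units; within the scatter) and a 1.0-fold higher number from compound 2 to compound 3 (0.02 log units; within the scatter), all fall within the scatter.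

Compound 4 `CN(C)CC(=O)N1CCC[C@H]1C(=O)N1CCC(NS(=O)(=O)c2cc(S(=O)(=O)c3ccccc3)ccc2C(F)(F)F)CC1` is compound 3 with one change: dimethylamino in place of hydrogen on a saturated chain carbon bound to a carbonyl carbon. This change sits in the same outer part of the molecule that was varied among compounds 1, 2 and 3 without effect beyond the scatter, so a step of similar size is expected here, that is, none beyond the scatter. For compound 4 the expected value is 250 nM, with a range from 120 nM to 520 nM; this expectation means a step of no change at the digits printed from compound 3 to compound 4 (within the scatter).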

Compound 4, half-maximal effective concentration: 310 nM
The estimate for compound 4 lay 1.2-fold (0.09 log units) below the measured number, within the range that was stated.
By their numbers in this assay, from the lowest: compounds 1, 2, 3 and 4 (each within the scatter of the next).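

In this assay the added dimethylamino on a saturated chain carbon bound to a carbonyl carbon gives a 1.2-fold higher number from compound 3 to compound 4 (0.09 log units; within the scatter) and so stays within the scatter; unlike the earlier changes, which swapped one group on the pyrrolidine nitrogen for another, this one extends the acetyl end with a group that holds a nitrogen. The comparisons a 1.3-fold higher number from compound 2 to compound 4 (0.11 log units; within the scatter) and a 1.5-fold higher number from compound 1 to compound 4 (0.17 log units; within the scatter) are also within the scatter, so the four compounds cannot be placed in any order. No measurement at hand offers an explanation for this result.

As far as these compounds go, whether a longer chain carrying the same amine, a morpholine or a carboxylic acid in place of dimethylamino would move the number beyond the scatter remains open. From the compounds shown here alone, it is also open whether any group at this end can do so at all.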